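Ether in place of amine on the shared core

A few compounds are considered here, and "the series" means these few. Any claim that something is new, unique, unknown or untested is made for them only; others in the source may bear on it.

Measured so far:
compound 1 `Cc1nc(N2CCCCC2)c2nnn(-c3ccc(C(C)C)cc3Br)c2n1`, an in vitro assay on 293-EBNA cells for binding affinity to corticotropin-releasing factor receptor 1 (Homo sapiens) (a lower number here means a stronger inhibitor, a higher number a weaker inhibitor), 46 nM
compound 2 `CCCCC(CC)Nc1nc(C)nc2c1nnn2-c1ccc(C(C)C)cc1Br`, this assay 3.1 nM

Compound 2 holds the lower of the two numbers; the step of a 15-fold lower number from compound 1 to compound 2 (1.17 log units; beyond the scatter) is the only one recorded, and it concerns a swap of one nitrogen-linked group for another. Compound 3 `CCC(COC)Oc1nc(C)nc2c1nnn2-c1ccc(C(C)C)cc1Br` carries 1-(methoxymethyl)propoxy in place of (1-ethylpentyl)amino on an aromatic carbon. Within the data shown here, no measured step covers an oxygen-linked group at this position, so the single large amine step gives only loose guidance. Compound 3 is expected to give a moderately higher number, an estimated 4.8-fold higher number from compound 2 to compound 3 (0.68 log units; beyond the scatter), thus 15 nM within 3 nM to 80 nM.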

Compound 3, inhibition constant: 1.9 nM
For compound 3 the middle estimate is 7.9-fold (0.90 log units) above the measured one; measured number below the stated range.
By their numbers in this assay, from the lowest: compounds 3 and 2 (each within the scatter of the next); then compound 1.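

In this assay, 1-(methoxymethyl)propoxy in place of (1-ethylpentyl)amino gives a 1.6-fold lower number from compound 2 to compound 3 (0.21 log units; within the scatter) and so stays within the scatter, showing that this position tolerates an oxygen link and the loss of the hydrogen-bond donor in this pair. Against piperidin-1-yl, the same ether gives a 24-fold lower number from compound 1 to compound 3 (1.38 log units; beyond the scatter) and so stays clearly ahead. No available measurement explains either step.

Going by these compounds, because both the linking atom and the chain differ between compound 2 and compound 3, their separate contributions remain open. A 1-ethylpentyloxy group would keep the chain of compound 2 and change only the link, while a 1-ethylpropoxy group would test the need for the methoxy oxygen.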